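Sulfamoyl in place of chloro on the shared core

The source may hold more compounds than are shown below. What is called first, only, known or untested is meant among the compounds shown, and "the series" means these compounds.

Measured compounds:
compound 1 `N#CC1=C(N)Oc2c(c3nc4ccccc4nc3c3ccccc23)C12C(=O)N(Cc1cnnn1-c1cccc(Cl)c1)c1ccccc12`, > 50000 nM
compound 2 `CCOc1ccc(-n2nncc2CN2C(=O)C3(C(C#N)=C(N)Oc4c3c3nc5ccccc5nc3c3ccccc43)c3ccccc32)cc1`, > 50000 nM

In an ADME assay on HUVEC cells (Homo sapiens) for antiproliferative activity, read by MTT assay, with a stated time of 48 h (on this read-out lower numbers stand for stronger inhibition and higher numbers for weaker inhibition), compound 1 gives > 50000 nM, which is a limit of the assay rather than a measured number. Compound 2 likewise gives > 50000 nM in this assay, again a limit. Among the compounds with values here, the step that the two limits leave unreadable from compound 1 to compound 2 is therefore unreadable, because both values sit at the limit of > 50000 nM in this assay, at which 2 of the 2 values shown sit, and this is the only measured step available.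

Compound 3 `N#CC1=C(N)Oc2c(c3nc4ccccc4nc3c3ccccc23)C12C(=O)N(Cc1cnnn1-c1cccc(S(N)(=O)=O)c1)c1ccccc12` differs from compound 1 by sulfamoyl in place of chloro on an aromatic carbon. Within the data shown here, no measured step involves this exchange, and the one step that is known gives no readable size in either direction, so there is no basis for expecting a change beyond the scatter in this assay. Compound 3 is therefore expected to stay at the same limit as compound 1, and the step that the limit leaves unreadable from compound 1 to compound 3 is estimated to be flat. The estimate for compound 3 in this assay is 60000 nM, expected to lie between 20000 nM and 150000 nM, with the most likely outcome being that only a limit is reported again.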

Compound 3, half-maximal inhibitory concentration: 38600 nM
The estimate for compound 3 lay 1.6-fold (0.19 log units) above the measured number; measured number inside the range.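

In this assay compound 3 gives 38600 nM, the first value among the compounds shown that is a measured number and not a limit, so this position on the phenyl ring now has one readable result. Sulfamoyl in place of chloro gives an at least 1.2-fold lower number from compound 1 to compound 3 (0.11 log units; that floor lies within the scatter), and 3-sulfamoylphenyl in place of 4-ethoxyphenyl gives an at least 1.2-fold lower number from compound 2 to compound 3 (0.11 log units; that floor lies within the scatter); each figure is only a floor, so neither exchange can yet be said to do more than fall within the usual variation between repeats. The true size of both steps stays unknown and the step between compound 1 and compound 2 cannot be read, because those two compounds give only limits: the limit of > 50000 nM in this assay, at which 2 of the 3 values shown sit.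

From the compounds shown here alone, it remains open whether an amine, a carboxylic acid or a methylsulfonyl group at this same place would bring the number clearly below that of compound 3. Going by these compounds, it is also open whether sulfamoyl would give a similar result on another carbon of this ring, or whether a longer chain on its nitrogen would shift the number further.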